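Oxetane Ether Extension and Expected Mouse Microsomal Clearance

A few compounds are considered here, and "the series" means these few. Any claim that something is new, unique, unknown or untested is made for them only; others in the source may bear on it.

Measured compounds in an in vitro ADME assay on microsomes from liver (Mus musculus) for metabolic stability, tested at 0.2 uM; a higher number here means faster removal of the compound, a lower number slower removal:
Compound 1 `Cc1c(COc2ccnc(OCC3CCOCC3)c2)[nH]c2ccccc2c1=O`: 203 mL/min/kg
Compound 2 `Cc1c(COCCCCO)[nH]c2ccccc2c1=O`: "not determined" (no result reported) (no result reported)
Compound 3 `COCCOCCCCc1[nH]c2ccccc2c(=O)c1C`: > 1000 mL/min/kg, which is a limit of the assay and not a number

Compound 2 therefore stands nowhere on the numbers shown: it carries no single value in this assay, so it cannot be placed against compound 1 or compound 3. Compound 1 gives a measured figure, while compound 3 sits at the limit of > 1000 mL/min/kg in this assay, at which 1 of the 3 values shown sits, and is known only as a limit.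

Compound 4 `Cc1c(COCCCCOCC2(C)COC2)[nH]c2ccccc2c1=O` differs from compound 2 in one place: (3-methyloxetan-3-yl)methyl in place of hydrogen on an oxygen on a saturated carbon. Cut one bond further out, this reads as hydroxy becoming (3-methyloxetan-3-yl)methoxy.

Since compound 2 has no value, no step can be read, and the expectation for compound 4 rests on the two neighbours alone. Compound 4 is expected to be cleared quickly in this assay, with a fair chance that only a limit is reported. Compound 4 is estimated at 700 mL/min/kg, with a likely range from 250 mL/min/kg to 1000 mL/min/kg.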

Compound 4, clearance: 295 mL/min/kg
Beside the measured number, compound 4's estimate is 2.4-fold (0.38 log units) above it; low and high end bracket the measured number.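

Going by these compounds alone, compound 2 carries no single value in this assay, so no step from it to compound 4 can be read. What putting (3-methyloxetan-3-yl)methyl in place of hydrogen does to clearance therefore stays open, and nothing shown here bears on that question.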